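The source may hold more compounds than are shown below. What is called first, only, known or untested is meant among the compounds shown, and "the series" means these compounds.

Working notes on the series. In an ADME assay on BHK-21 cells (Mesocricetus auratus) for cytotoxicity, read by MTT assay, with a stated time of 96 h (a higher number here means that more compound is tolerated, a lower number that less compound is tolerated), compound 3 (`Fc1ccc(F)c(/N=N/Nc2cccc(C(F)(F)F)c2)c1`) gives > 100000 nM, which is a limit of the assay and not a number. Compound 1 (`c1ccc(/N=N/N2CCN(c3ccccc3)CC2)cc1`) gives > 100000 nM, also a limit. Compound 3 therefore stands at the limit of > 100000 nM in this assay, at which 2 of the 3 values shown sit, so its true position is not known. Within the data shown here, compound 2 (`CN(C)CCCN(/N=N/c1c(F)cccc1F)c1ccccc1`) is the only compound with a number so far, at 52000 nM.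

Compound 4 (`CN(C)CCCN(/N=N/c1cc(F)ccc1F)c1cccc(C(F)(F)F)c1`) follows from compound 3 by one change, 3-(dimethylamino)propyl in place of hydrogen on a nitrogen on an aromatic ring. Among the measured compounds shown here, no measured pair isolates this change. For the measured compounds named here, the one guide is compound 2, which also carries 3-(dimethylamino)propyl and gives 52000 nM. A move towards less compound tolerated in this assay is therefore expected, of moderate size and beyond the scatter. The estimated change is an at least 2.5-fold lower number from compound 3 to compound 4 (0.39 log units; beyond the scatter), counted from a limit and so only approximate. For compound 4 the estimate is 40000 nM, with an expected range of 14000 nM to 100000 nM.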

Compound 4, half-maximal cytotoxic concentration: 54000 nM
The estimate for compound 4 lay 1.4-fold (0.13 log units) below the measured number; measured number inside the range.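

Among these compounds, this is the first measured pair to isolate 3-(dimethylamino)propyl in place of hydrogen on a nitrogen on an aromatic ring, and in this assay it reads an at least 1.8-fold lower number from compound 3 to compound 4 (0.26 log units; that floor lies within the scatter). Compound 3 gives > 100000 nM, which is a limit of the assay, so the hydrogen side of this pair has no number. The floor of the step does not clear the scatter, so this pair alone does not establish a change, and its true size stays unread because of where compound 3 stands: the limit of > 100000 nM in this assay, at which 2 of the 4 values shown sit.

Whether any shift belongs to the propyl chain or to the dimethylamino group stays open; no pair shown separates the two. A 3-hydroxypropyl or a 2-(dimethylamino)ethyl on the same nitrogen would bear on that question.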